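This account rests on a few compounds, and the source may have more. Where it says the series, first, only, none or still open, it means among the compounds named here.

Compound 3 `C=C(c1cc(OC)cc(OC)c1)c1ccc(OC)c(OC)c1` is the starting point of this step. In a functional assay on HCT-116 cells (Homo sapiens) for cytotoxicity, read by scintillation counting and thymidine incorporation, with a stated time of 72 h (a higher number here means a weaker inhibitor, a lower number a stronger inhibitor), compound 3 gives > 10000 nM, which is a limit of the assay rather than a number. Compound 1 `COc1cc(OC)cc(C(=CC(N)=O)c2ccc(OC)c(OC)c2)c1` is measured in this assay at > 10000 nM, again a limit. Compound 2 `C#CC=C(c1cc(OC)cc(OC)c1)c1ccc(OC)c(OC)c1` stands in this assay at > 10000 nM, also a limit. All three values sit at the same boundary (the limit of > 10000 nM in this assay, at which 3 of the 3 values shown sit), so none of the steps among them can be sized: a step that the two limits leave unreadable from compound 1 to compound 2, a step that the two limits leave unreadable from compound 1 to compound 3 and a step that the two limits leave unreadable from compound 2 to compound 3 are each unreadable. Compound 4 `CC=C(c1cc(OC)cc(OC)c1)c1ccc(OC)c(OC)c1` has not yet been measured. It differs from compound 3 by methyl in place of hydrogen on a double-bonded chain carbon bound to a double-bonded chain carbon. The change is small, and the three measured steps, all exchanges on a double-bonded chain carbon bound to a double-bonded chain carbon, give no readable size, so no step beyond the scatter is expected in this assay. The expected step is a step that the limit leaves unreadable from compound 3 to compound 4. Compound 4 is therefore estimated in this assay at 12000 nM, within 3000 nM to 40000 nM, quite possibly reported only as a limit.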

Compound 4, half-maximal inhibitory concentration: 480 nM
Estimate against measurement, compound 4: 25-fold (1.40 log units) above; measured number below the stated range.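

In this assay, this position on a double-bonded chain carbon bound to a double-bonded chain carbon now yields readable steps, and all of them involve methyl. Replacing hydrogen with methyl gives an at least 20-fold lower number from compound 3 to compound 4 (1.31 log units; beyond the scatter), while replacing ethynyl with methyl gives an at least 20-fold lower number from compound 2 to compound 4 (1.31 log units; beyond the scatter), and replacing carbamoyl with methyl gives an at least 20-fold lower number from compound 1 to compound 4 (1.31 log units; beyond the scatter). So a change of 1 heavy atom can produce a large step here, but these sizes are bounds, and the steps among compound 1, compound 2 and compound 3 cannot be read: the limit of > 10000 nM in this assay, at which 3 of the 4 values shown sit.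

From the compounds shown here alone, whether a longer chain such as ethyl or propyl at this carbon would hold, raise or lower the number of compound 4 remains open. The same is true of a hydroxymethyl group, an aminomethyl group or a fluorine atom in this place.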